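A few compounds are considered here, and "the series" means these few. Any claim that something is new, unique, unknown or untested is made for them only; others in the source may bear on it.

Working notes on a small series. Within the data shown here, compound 1 `COc1cc2c(cc1O)O[C@H](c1ccccc1)CC2=O` is the only member with a numerical result: in a functional assay on A549 cells (Homo sapiens) for cytotoxicity, read by MTT assay, with a stated time of 72 h (on this read-out higher numbers stand for weaker inhibition and lower numbers for stronger inhibition), compound 1 gives 8600 nM. For compound 2 `O=C1C[C@@H](c2ccccc2)Oc2cc(O)c(O)c(O)c21` the assay reports only a limit, > 100000 nM. Compound 3 `O=C1c2ccc(O)cc2O[C@H](c2ccccc2)[C@H]1O` likewise reaches only a limit, > 100000 nM. Compound 3 thus stands at the limit of > 100000 nM in this assay, at which 2 of the 3 values shown sit, with nothing in the numbers to separate it from compound 2. Compound 4 `COc1cc2c(cc1O)O[C@H](c1ccccc1)[C@@H](O)C2=O` differs from compound 3 by methoxy in place of hydrogen on an aromatic carbon. Among the measured compounds shown here, no measured pair isolates this change, so its size is not known from the series; compound 1, which also carries the methoxy group, sits at 8600 nM, so some movement into the measurable range is possible while weak inhibition is still expected. Compound 4 is expected near 60000 nM, between 15000 nM and 200000 nM. That corresponds to an expected step of an at least 1.6-fold lower number from compound 3 to compound 4 (0.22 log units; that floor lies within the scatter).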

Compound 4, half-maximal inhibitory concentration: > 100000 nM
Compound 4 gave a limit, no number; the forecaster's own chance of this, stated with the estimate: 50%; at least 1.6-fold (0.22 log units) between middle value and limit.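

Hydroxy in place of hydrogen on a saturated ring carbon, with the methoxy group kept, gives a large move toward weaker inhibition in this assay: an at least 11-fold higher number from compound 1 to compound 4 (1.06 log units; beyond the scatter). The step for methoxy in place of hydrogen on an aromatic carbon cannot be read, and with the hydroxy present, methoxy does not bring the compound to a number. Only compound 1 gives a number, and the others rest on a limit: the limit of > 100000 nM in this assay, at which 3 of the 4 values shown sit.

As far as these compounds go, how far compound 3 and compound 4 lie past that limit remains open. Also open, from the compounds shown here alone, is whether an amine on the same saturated ring carbon would keep a measurable value.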